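Replacing ethyl with 3-fluorophenyl on a carbonyl carbon

The compounds below may be only part of what the source reports. "The series", "measured", "known", "first", "only" and "open" are said of these compounds alone.

In a functional assay on WI-38 VA13 cells (Homo sapiens) for cytotoxicity (a higher number here means that more compound is needed for the effect, a lower number that less compound is needed), compound 1 (`CCOC(=O)c1sc2nc(-c3cccs3)ccc2c1N`) gives only a limit (> 4 ug/mL). Going by the values given here, compound 2 (`CCC(=O)c1sc2nc(-c3cccs3)ccc2c1N`) gives the only actual number so far (0.89 ug/mL). Compound 3 (`Nc1c(C(=O)c2cccc(F)c2)sc2nc(-c3cccs3)ccc12`) carries 3-fluorophenyl in place of ethyl on a carbonyl carbon. Among the compounds with values here, one measured step bears on this change, since it falls on the same carbonyl carbon, with ethyl in place of ethoxy (an at least 4.4-fold lower number from compound 1 to compound 2 (0.65 log units; beyond the scatter)). That step shows that this assay responds to a change at this place, but it involved no ring, so its size cannot simply be carried over. An estimated step (a 1.7-fold higher number from compound 2 to compound 3 (0.23 log units; within the scatter)) is therefore expected to stay within the scatter, leaning slightly towards a higher number. The estimate for compound 3 is 1.5 ug/mL with an expected range (0.4 ug/mL to 4.5 ug/mL).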

Compound 3, half-maximal effective concentration: 0.025 ug/mL
For compound 3 the middle estimate is 60-fold (1.78 log units) above the measured one; the measured number lies below the stated range.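

Compounds 1 and 2 showed that this assay responds to a change at this carbonyl carbon, but neither carries a ring there. Compound 3 brings the first ring to this place, and the result is a 36-fold lower number from compound 2 to compound 3 (1.55 log units; beyond the scatter). So 3-fluorophenyl on this carbonyl carbon goes with far less compound needed than ethyl, and the comparison with ethoxy gives an at least 160-fold lower number from compound 1 to compound 3 (2.20 log units; beyond the scatter), a step that rests on a limit and not on a number for compound 1: the limit of > 4 ug/mL in this assay, at which 1 of the 3 values shown sits.

The compounds shown leave open whether the ring alone accounts for this step or the fluorine takes part, which a plain phenyl or a chlorine in place of the fluorine would separate. Also open, from the compounds shown here alone, is whether a pyridyl ring or a longer chain such as butyl would behave in the same way.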